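The source may report more compounds than this note shows. Statements on the series, on what has been measured and on what is new or still open speak of the compounds shown alone.

In a functional assay on HCT-116 cells (Homo sapiens) for antiproliferative activity, read by MTT assay, with a stated time of 72 h (on this read-out lower numbers stand for stronger inhibition and higher numbers for weaker inhibition), compound 1 `CCOC(=O)c1csc2nc(CN3CCN(Cc4ccccc4)CC3)c(-c3ccc(OC)cc3)n12` gives 19600 nM; compound 2 `CCOC(=O)c1csc2nc(CN3CCN(Cc4ccccc4)CC3)c(-c3ccc(Br)cc3)n12` gives 37200 nM; compound 3 `COc1ccc(-c2cnc3scc(C(=O)NNC(C)=O)n23)cc1` gives 17000 nM.

Compound 1 and compound 2 share a core and differ by bromo in place of methoxy on an aromatic carbon, a change that made a 1.9-fold higher number from compound 1 to compound 2 (0.28 log units; within the scatter). Compound 3 is built on a different core; the difference between the two cores is not broken down here. Compound 3 and compound 1 stand within the scatter of each other, whereas the number for compound 2 lies beyond the scatter from that of compound 3. Compound 4 `CC(=O)NNC(=O)c1csc2ncc(-c3ccc(Br)cc3)n12` has not yet been measured; it differs from compound 3 by bromo in place of methoxy on an aromatic carbon, the same change as that between compound 1 and compound 2, at the same place. Compound 4 is expected to sit a 1.9-fold higher number from compound 3 to compound 4 (0.27 log units; within the scatter), an expectation that rests on the measured pair because a 1.9-fold higher number from compound 1 to compound 2 (0.28 log units; within the scatter). Compound 4 is therefore estimated at 32000 nM, with a likely range from 15000 nM to 70000 nM.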

Compound 4, half-maximal inhibitory concentration: 6080 nM
Compound 4: the middle estimate sits 5.3-fold (0.72 log units) above what was measured; measured number below the stated range.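

In this assay, bromo in place of methoxy on an aromatic carbon gave a 2.8-fold lower number from compound 3 to compound 4 (0.45 log units; beyond the scatter), so the step seen on the core of compound 1 did not carry over to the core of compound 3: the same change on two cores in this assay, a 1.9-fold higher number (0.28 log units; within the scatter) from compound 1 to compound 2 and a 2.8-fold lower number (0.45 log units; beyond the scatter) from compound 3 to compound 4, 5.3-fold (0.72 log units) apart, beyond the scatter of two such steps. Among the compounds shown here, in these two pairs, the outcome of this change depended on the core, and only the step on the core of compound 3 lies beyond the scatter. Two pairs do not show which part of the cores accounts for the gap, nor do they set a rule for the wider series.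

The compounds shown leave open whether chloro or an amine at the same place would also differ between the two cores. They also leave open whether the piperazine side chain or the ester alone would be enough to produce the gap.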